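A few compounds are considered here, and "the series" means these few. Any claim that something is new, unique, unknown or untested is made for them only; others in the source may bear on it.

Measured so far in a physicochemical assay for lipophilicity, read by HPLC, at pH 7.5; on this read-out higher numbers stand for higher lipophilicity and lower numbers for lower lipophilicity:
- compound 1 `CC[C@@H](Nc1c(C#N)c(-c2ccc(-c3ccccc3F)cc2)nc2cnccc12)C(N)=O` gives 2.7
- compound 2 `CCOc1ccccc1-c1ccc(-c2nc3cnccc3c(NC(C)C(=O)O)c2C#N)cc1` gives 2.1
- compound 3 `N#Cc1c(-c2ccc(Br)cc2)nc2cnccc2c1NCC(N)=O` gives 1.9

Compound 1 stands highest of the three, beyond the scatter from both compound 2 and compound 3. For the measured compounds named here, compound 4 `CC[C@@H](Nc1c(C#N)c(-c2ccc(-c3ccc(OC)cc3)cc2)nc2cnccc12)C(N)=O` has no measurement yet. Relative to compound 1, it carries 4-methoxyphenyl in place of 2-fluorophenyl on an aromatic carbon. Going by the values given here, no pair of measured compounds differs in one place only, so the expectation rests on this structural change alone: no step beyond the scatter in this assay, in either direction. The estimated step is small, with a number 0.10 log units higher from compound 1 to compound 4 (within the scatter) expected. For compound 4 the estimated value is 2.8, with an expected range from 2.4 to 3.2.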

Compound 4, distribution coefficient: 2.7
Compound 4: the middle estimate sits 0.10 log units above what was measured; the range from low to high includes it.
By their numbers in this assay, from the lowest: compounds 3 and 2 (each within the scatter of the next); then compounds 1 and 4 (each within the scatter of the next).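

In this assay, for the compounds shown here, the first single-place step shows 4-methoxyphenyl in place of 2-fluorophenyl giving no change at the digits printed from compound 1 to compound 4 (within the scatter). At this position, then, the exchange of a fluorine-bearing ring for one with a hydrogen-bond acceptor leaves the read-out within the scatter, although the two substituents change together and their separate contributions cannot be read. No measured evidence accounts for this flat result. From the compounds shown here alone, whether an amine or a carboxylic acid in this place would move the read-out remains open. So does the outcome of an unsubstituted phenyl here.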